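The source may hold more compounds than are shown below. What is called first, only, known or untested is meant among the compounds shown, and "the series" means these compounds.

Of the compounds shown here, three have so far been measured in a functional assay on A549 cells (Homo sapiens) for antiproliferative activity, with a stated time of 72 h; on this read-out higher numbers stand for weaker inhibition and lower numbers for stronger inhibition. Compound 1 `CCN(C)Cc1c(OC)cc(OC)c(C(=O)/C=C/c2ccccc2Cl)c1O` gives 1300 nM. Compound 3 `COc1cc(OC)c(C(=O)/C=C/c2ccccc2Cl)c(O)c1CN1CCCCC1` gives 2800 nM, the higher of the two numbers; the distance between them is the step of a 2.2-fold higher number from compound 1 to compound 3 (0.33 log units; beyond the scatter), in which piperidin-1-yl replaces ethyl(methyl)amino on a saturated chain carbon bound to an aromatic carbon. Compound 2 `COc1cc(OC)c2c(=O)cc(-c3ccccc3Cl)oc2c1CN1CCCCC1` yields no number at all, only a limit of the assay, > 150000 nM, as noted in the limit of > 150000 nM in this assay, at which 1 of the 3 values shown sits.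

Compound 4 `COc1cc(OC)c(C(=O)/C=C/c2ccccc2Cl)c(O)c1CN(C)CC(=O)O` is the next to be measured. It differs from compound 3 in one place: (carboxymethyl)(methyl)amino in place of piperidin-1-yl on a saturated chain carbon bound to an aromatic carbon. Within the data shown here, the only measured step at this position is a 2.2-fold higher number from compound 1 to compound 3 (0.33 log units; beyond the scatter), which was modest; it exchanged one nitrogen group for another, whereas here a ring gives way to a chain carrying a carboxylic acid, a change of a different kind. A modest rise in number, somewhat larger than that step, is therefore the expectation. The expected step is a 2.9-fold higher number from compound 3 to compound 4 (0.46 log units; beyond the scatter). Compound 4 is estimated at 8000 nM, with a range from 2500 nM to 25000 nM.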

Compound 4, half-maximal inhibitory concentration: 79400 nM
Compound 4: middle estimate off by 9.9-fold (1.00 log units), on the low side; the whole stated range lies below it.
By their numbers in this assay, from the lowest: compound 1; then compound 3; then compound 4. At a limit, above all of these: compound 2.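

The change at this place, on a saturated chain carbon bound to an aromatic carbon, matters far more than the earlier swap of one nitrogen group for another suggested: a 2.2-fold higher number from compound 1 to compound 3 (0.33 log units; beyond the scatter) was modest, while a 28-fold higher number from compound 3 to compound 4 (1.45 log units; beyond the scatter) is large. Losing the ring alone does not account for this, since compound 1 also has no ring here, and carboxy in place of methyl on a saturated chain carbon bound to an amine nitrogen gives a 61-fold higher number from compound 1 to compound 4 (1.79 log units; beyond the scatter). The values shown say how large this weakening is but offer no measured reason for it.

As far as these compounds go, it stays open whether the weakening needs the free carboxylic acid or would also appear with a methyl ester or a primary amide at the same chain end. A longer chain carrying the acid, with one more carbon before the carboxy group, is equally unsettled.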